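The compounds below may be only part of what the source reports. "The series", "measured", "known", "first", "only" and "open" are said of these compounds alone.

In an ADME assay on NHDF cells (Homo sapiens) for cytotoxicity, read by MTT assay, with a stated time of 72 h (a lower number here means a stronger inhibitor, a higher number a weaker inhibitor), compound 1 `COc1cccc(/C=C2\CCC/C(=C\c3cccc(Cl)c3)C2=O)c1OC` gives 21400 nM and compound 2 `COc1ccc(/C=C2\CCC/C(=C\c3ccccc3Br)C2=O)cc1OC` gives 21800 nM. These two numbers lie within the scatter of each other, so compound 2 stands level with compound 1. Compound 3 `COc1ccc(/C=C2\CCC/C(=C\c3cccc(O)c3)C2=O)cc1OC` differs from compound 2 in one place: 3-hydroxyphenyl in place of 2-bromophenyl on a double-bonded chain carbon bound to a double-bonded ring carbon. Among the compounds with values here, no measured pair here shows what a single change of this kind does, so the expectation for this assay is no step beyond the scatter. The estimated value for compound 3 is 18000 nM, with an expected range from 7000 nM to 45000 nM.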

Compound 3, half-maximal inhibitory concentration: 6800 nM
Compound 3: the middle estimate sits 2.6-fold (0.42 log units) above what was measured; the measured number lies below the stated range.
By their numbers in this assay, from the lowest: compound 3; then compounds 1 and 2 (each within the scatter of the next).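

In this assay the group on a double-bonded chain carbon bound to a double-bonded ring carbon can move the number: there is a 3.2-fold lower number from compound 2 to compound 3 (0.51 log units; beyond the scatter) when 3-hydroxyphenyl takes the place of 2-bromophenyl. The heavy-atom count stays the same, while the hydrogen-bond donor and acceptor counts rise. No measurement here explains the step.

The compounds shown do not separate the loss of bromine from the arrival of the hydroxyl group. As far as these compounds go, how a plain phenyl or a 3-aminophenyl group would behave in the same place remains open.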